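Swapping a nitro for a methyl on the benzyl arm

The source may hold more compounds than are shown below. What is called first, only, known or untested is meant among the compounds shown, and "the series" means these compounds.

Measured so far:
compound 1, `CS(=O)(=O)Nc1ccc([N+](=O)[O-])cc1OCc1ccc([N+](=O)[O-])cc1` — 400 nM
compound 2, `CS(=O)(=O)Nc1ccc([N+](=O)[O-])cc1OCc1ccccc1-c1ccccc1` — 260 nM

Two compounds share a core and differ only in the group carried on the benzyl arm. In an assay on SK-BR-3 cells for inhibition of Aromatase (Homo sapiens) (on this read-out lower numbers stand for stronger inhibition and higher numbers for weaker inhibition), compound 1 gives 400 nM. Compound 2 gives 260 nM in this assay; the two numbers lie within the scatter of each other, so no order between them can be read from this pair.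

Compound 3, `Cc1ccc(COc2cc([N+](=O)[O-])ccc2NS(C)(=O)=O)cc1`, has not yet been measured. It is compound 1 with one change: methyl in place of nitro on an aromatic carbon. Going by the values given here, no measured pair shows what such a change does here, so the step from compound 1 to compound 3 in this assay is expected to be small, possibly nothing beyond the scatter. Because compound 1 gives 400 nM, compound 3 is estimated at 350 nM, with a range from 120 nM to 1000 nM, and the expected step from compound 1 to compound 3 is a 1.1-fold lower number from compound 1 to compound 3 (0.06 log units; within the scatter).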

Compound 3, half-maximal inhibitory concentration: 1750 nM
Compound 3: the middle estimate sits 5.0-fold (0.70 log units) below what was measured, outside the stated range (above it).
By their numbers in this assay, from the lowest: compounds 2 and 1 (each within the scatter of the next); then compound 3.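

In this assay, methyl in place of nitro on this aromatic carbon, para to a large group, gives a 4.4-fold higher number from compound 1 to compound 3 (0.64 log units; beyond the scatter), which means weaker inhibition. Going by these compounds alone, this is the first step that lies beyond the scatter, so this position is not indifferent to what it carries, and of these two groups nitro goes with the stronger inhibition. Nothing available explains why the number moves in this way.

A single pair cannot show whether the step comes from losing the nitro or from gaining the methyl. On these data alone, it also remains open whether other groups on this carbon, such as an amine, a nitrile or a carboxylic acid, would stay close to compound 1 or move the number further.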